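Thiosemicarbazones with varied para substituent on the aryl ring

The compounds below may be only part of what the source reports. "The series", "measured", "known", "first", "only" and "open" are said of these compounds alone.

Measured so far:
compound 1 `COc1ccc(/C=N/NC(=S)NC(C)(C)[C@H]2CC=C(C)CC2)cc1` — 8400 nM
compound 2 `CC1=CC[C@H](C(C)(C)NC(=S)N/N=C/c2ccc(O)cc2)CC1` — > 100000 nM

Of the compounds shown here, two have been tested in a functional assay on HT-29 cells (Homo sapiens) for inhibition, read by sulforhodamine B assay, with a stated time of 48 h; on this read-out lower numbers stand for stronger inhibition of growth and higher numbers for weaker inhibition of growth. Compound 1 gives 8400 nM. For compound 2 only a limit of the assay is reported, > 100000 nM, so compound 2 stands at the weak end of what has been measured, and its true number is not known; this follows from the limit of > 100000 nM in this assay, at which 1 of the 2 values shown sits. Among the measured compounds shown here, the single measured step runs an at least 11-fold higher number from compound 1 to compound 2 (1.07 log units; beyond the scatter), the change being hydrogen in place of methyl on an oxygen on an aromatic ring.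

Compound 3 `CC1=CC[C@H](C(C)(C)NC(=S)N/N=C/c2ccc(N(C)C)cc2)CC1` is not yet measured. It differs from compound 2 by dimethylamino in place of hydroxy on an aromatic carbon of a six-membered aromatic ring of carbon only, para to a large group. The step from compound 1 to compound 2 is the only one that bears on this position; it was large, and it runs in the direction of the hydroxy compound being weaker. Replacing hydroxy with dimethylamino is therefore expected to move the number in this assay back downward, with compound 3 estimated at 5000 nM (range 1500 nM to 30000 nM), an expected step of an at least 20-fold lower number from compound 2 to compound 3 (1.30 log units; beyond the scatter).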

Compound 3, concentration for 50% growth inhibition: 46500 nM
The estimate for compound 3 lay 9.3-fold (0.97 log units) below the measured number; measured number above the stated range.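

In this assay, dimethylamino in place of hydroxy gives an at least 2.1-fold lower number from compound 2 to compound 3 (0.33 log units; beyond the scatter), so the weak end of the series at this position is not a feature of every group other than methoxy. Dimethylamino in place of methoxy gives a 5.5-fold higher number from compound 1 to compound 3 (0.74 log units; beyond the scatter), which shows that the choice of group on this aromatic carbon still matters once hydroxy is gone, and that among the three compounds shown, methoxy in compound 1 gives the strongest inhibition of growth. For compound 2 the reported value is a limit and not a number, so the step out of compound 2 fixes only a minimum size and the true gap stays unknown: the limit of > 100000 nM in this assay, at which 1 of the 3 values shown sits.

Going by these compounds, whether the advantage of methoxy extends to a longer chain on the oxygen, such as ethoxy, or whether a group without oxygen or nitrogen, such as methyl, chlorine or trifluoromethyl, can match or pass compound 1 remains open. The compounds shown also leave open whether the order of methoxy, dimethylamino and hydroxy holds on other cell lines or with a different group on the far side of the shared core.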